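The source may report more compounds than this note shows. Statements on the series, on what has been measured and on what is new or still open speak of the compounds shown alone.

In a functional assay on NCI-H460 cells (Homo sapiens) for inhibition, read by MTT assay, with a stated time of 72 h (on this read-out higher numbers stand for weaker inhibition and lower numbers for stronger inhibition), compound 1 `COc1cc2c(Oc3ccc(NC(=O)c4nn(-c5ccccc5OC(F)(F)F)c(=O)cc4C)cc3F)ccnc2cc1OCCCN1CCCC1` gives 210 nM, the lowest of the two numbers shown. Compound 2 `COc1cc2c(Oc3ccc(NC(=O)c4nn(-c5ccccc5OC(F)(F)F)c(=O)cc4C)cc3F)ccnc2cc1OCCCN1CCCCC1` gives 230 nM in this assay, and the step of a 1.1-fold higher number from compound 1 to compound 2 (0.04 log units; within the scatter) is within the scatter. Compound 3 `COc1cc2c(Oc3ccc(NC(=O)c4nn(-c5ccc(F)c(F)c5)c(=O)cc4C)cc3F)ccnc2cc1OCCCN1CCCC1` differs from compound 1 by 3,4-difluorophenyl in place of 2-(trifluoromethoxy)phenyl on an aromatic nitrogen. Among the measured compounds shown here, the single measured step touches a different part of the shared core, so no measured step bears on this change, and the expectation rests on compound 1 alone. The expected step is a 1.4-fold higher number from compound 1 to compound 3 (0.15 log units; within the scatter), small and uncertain in direction. Compound 3 is estimated at 300 nM, with a range from 100 nM to 1000 nM.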

Compound 3, half-maximal inhibitory concentration: 170 nM
Compound 3: the middle estimate sits 1.8-fold (0.25 log units) above what was measured; measured number inside the range.
By their numbers in this assay, from the lowest: compounds 3, 1 and 2 (each within the scatter of the next).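

Among the compounds shown here, on the aromatic nitrogen, the step from 2-(trifluoromethoxy)phenyl to 3,4-difluorophenyl gives a 1.2-fold lower number from compound 1 to compound 3 (0.09 log units; within the scatter) in this assay and is the first measured change at this position. The entering group has fewer heavy atoms than the group it replaces and no hydrogen-bond acceptor, yet the two values stay within the scatter of each other. Nothing available explains why these two groups read alike. Still open, on these data alone, is how a plain phenyl or a cyclohexyl group on this nitrogen would read. Also open, as far as these compounds go, is whether piperidin-1-yl would match pyrrolidin-1-yl alongside 3,4-difluorophenyl.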